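The compounds below may be only part of what the source reports. "The series", "measured", "known", "first", "only" and "open" are said of these compounds alone.

Compounds measured in a functional assay on SF-295 cells (Homo sapiens) for antiproliferative activity, read by sulforhodamine B assay, with a stated time of 72 h; a lower number here means a stronger inhibitor, a higher number a weaker inhibitor:
- compound 1, `Cc1cc(NS(=O)(=O)c2ccc(Nc3nncc4ccccc34)cc2)no1`: 4.4 nM
- compound 2, `NS(=O)(=O)c1ccc(Nc2nncc3ccccc23)cc1`: 5.3 nM

For the measured compounds named here, compound 2 gives the highest of the two numbers so far, its only neighbour being compound 1 at a gap described by a 1.2-fold higher number from compound 1 to compound 2 (0.08 log units; within the scatter), so the two stand together. Compound 3, `N#Cc1ccc(Nc2nncc3ccccc23)cc1`, is not yet measured; it differs from compound 2 by cyano in place of sulfamoyl on an aromatic carbon. Going by the values given here, the one known step, a 1.2-fold higher number from compound 1 to compound 2 (0.08 log units; within the scatter), touches the sulfonamide nitrogen and lies within the scatter, so it speaks only loosely to an exchange of the whole sulfamoyl group. A modest loss is expected for compound 3, a 2.8-fold higher number from compound 2 to compound 3 (0.45 log units; beyond the scatter). Compound 3 is estimated at 15 nM, range 4 nM to 60 nM.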

Compound 3, half-maximal inhibitory concentration: 0.32 nM
Estimate against measurement, compound 3: 47-fold (1.67 log units) above, and the stated range ends above it.
By their numbers in this assay, from the lowest: compound 3; then compounds 1 and 2 (each within the scatter of the next).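

In this assay, the group on this aromatic carbon, para to a large group, carries far more weight than the substituent on the sulfonamide nitrogen: a 17-fold lower number from compound 2 to compound 3 (1.22 log units; beyond the scatter), against a 1.2-fold higher number from compound 1 to compound 2 (0.08 log units; within the scatter). Sulfamoyl is therefore not needed for activity in this series, and cyano, with no hydrogen-bond donor, does much better in its place. Nothing available explains the size of this gain.

From the compounds shown here alone, whether the gain is specific to cyano remains open. A carboxylic acid, an amine or a chlorine atom on the same carbon would test this.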